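A few compounds are considered here, and "the series" means these few. Any claim that something is new, unique, unknown or untested is made for them only; others in the source may bear on it.

Compound 1 `O=C1N(CCCCCCOc2ccc(Cl)cc2)CCN1c1cccnc1`. In a functional assay on cells (Homo sapiens) for cytotoxicity (a lower number here means that less compound is tolerated, a higher number that more compound is tolerated), compound 1 gives only the limit > 25000 nM.
Compound 2 `O=C1N(CCCCCCOc2ccc(Cl)cc2)CCN1c1ccncn1`. In this assay compound 2 gives only the limit > 25000 nM.
Compound 3 `O=C1N(CCCCCCCOc2ccc(Br)cc2)CCN1c1ccncn1`. In this assay compound 3 gives only the limit > 25000 nM.

Compound 2 therefore stands at a limit rather than at a number, and the two further values shown for the series are limits as well, as the limit of > 25000 nM in this assay, at which 3 of the 3 values shown sit, records. The two measured steps are a step that the two limits leave unreadable from compound 1 to compound 2 and a step that the two limits leave unreadable from compound 2 to compound 3; neither gives a size, since both ends of each step sit at the limit.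

Compound 4 `O=C1N(CCCCCCOc2ccc(Cl)cc2)CCN1c1ccccc1` has not yet been tested in this assay. It differs from compound 2 by phenyl in place of pyrimidin-4-yl on an amide-type nitrogen in a ring. Both measured steps bear on this change only loosely: the first exchanges one six-membered aromatic ring with hetero atoms for another on the same nitrogen, the second alters the chain end, and neither could be read. With three limits and no readable step, the expectation for compound 4 is that it behaves like compound 2 and reaches the limit again, so the step that the limit leaves unreadable from compound 2 to compound 4 is estimated as none beyond the scatter. The estimate for compound 4 in this assay is 30000 nM, expected to fall between 10000 nM and 90000 nM.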

Compound 4, half-maximal cytotoxic concentration: > 25000 nM
Compound 4: a limit, no number; the forecaster's own chance of this, stated with the estimate: 80%; the middle value lies beyond the limit too.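

In this assay compound 4 gives only a limit, > 25000 nM. No new step can be read, since compound 1, compound 2 and compound 4 all sit at one limit: the limit of > 25000 nM in this assay, at which 4 of the 4 values shown sit. The compounds shown leave open where any of them would give an actual number in this assay, and whether exchanging the aromatic ring on the nitrogen changes that number.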